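Fluoro to methoxy exchange across two cores

A few compounds are considered here, and "the series" means these few. Any claim that something is new, unique, unknown or untested is made for them only; others in the source may bear on it.

Measured so far:
compound 1 `COc1ccc2c(/C=C(\C#N)C(=O)c3c[nH]c4cc(OC)ccc34)c[nH]c2c1`: 1700 nM
compound 2 `N#C/C(=C\c1cn(Cc2ccc(Cl)cc2)c2ccccc12)C(=O)c1c[nH]c2cc(F)ccc12`: > 50000 nM (a limit of the assay)
compound 3 `COc1ccc2c(C(=O)/C(C#N)=C/c3c[nH]c4cc(F)ccc34)c[nH]c2c1`: 800 nM

In a functional assay on A549 cells (Homo sapiens) for cytotoxicity, read by WST assay, with a stated time of 48 h (on this read-out higher numbers stand for weaker inhibition and lower numbers for stronger inhibition), compound 3 gives 800 nM. Going by the values given here, compound 1 gives 1700 nM, so the step of a 2.1-fold higher number from compound 3 to compound 1 (0.33 log units; beyond the scatter) is the single change (methoxy in place of fluoro on an aromatic carbon). For compound 2 only a limit is known, > 50000 nM; it sits at the limit of > 50000 nM in this assay, at which 1 of the 3 values shown sits. How the core of compound 2 differs from the core of compound 3 is not broken down here.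

Compound 4 `COc1ccc2c(C(=O)/C(C#N)=C/c3cn(Cc4ccc(Cl)cc4)c4ccccc34)c[nH]c2c1` is not yet measured. It differs from compound 2 by methoxy in place of fluoro on an aromatic carbon, the same change as from compound 3 to compound 1, made at the same place. The expected step is a step that the limit leaves unreadable from compound 2 to compound 4, which rests on the measured step of a 2.1-fold higher number from compound 3 to compound 1 (0.33 log units; beyond the scatter) taken as a guide. Since the value of compound 2 is a limit, a weakening of that size is expected to leave compound 4 most likely at a limit as well. Compound 4 is therefore estimated at 80000 nM, with a range from 25000 nM to 250000 nM.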

Compound 4, half-maximal inhibitory concentration: > 50000 nM
Compound 4: only a limit was reported; the forecaster's own chance of this, stated with the estimate: 75%; the middle value does not contradict the limit.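

Compound 4 gives > 50000 nM, a limit of the assay. Compound 2 stands at a limit too, so the exchange of fluoro for methoxy between these two compounds yields no readable step: the limit of > 50000 nM in this assay, at which 2 of the 4 values shown sit.

The compounds shown leave open whether this exchange changes the read-out at all on the core of compound 2.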